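A few compounds are considered here, and "the series" means these few. Any claim that something is new, unique, unknown or untested is made for them only; others in the source may bear on it.

Of the compounds shown here, three of one series have been measured in a functional assay on T47D cells (Homo sapiens) for cytotoxicity, read by CCK-8 assay and cell counting, with a stated time of 72 h; on this read-out higher numbers stand for weaker inhibition and lower numbers for stronger inhibition. Compound 1 `COc1ccc(-c2cc3ccccc3c(-c3ccc(OC)cc3)n2)cc1` gives 850 nM. Compound 2 `COc1cccc(-c2nc(-c3ccc(OC)c(OC)c3)cc3cc(C)ccc23)c1` gives 7860 nM. Compound 3 `COc1ccc(-c2cc3cc(C)ccc3c(-c3cccc(N)c3)n2)cc1OC` gives 450 nM, the lowest number of the three, although the gap to compound 1 lies within the scatter of the method, so no order between compound 3 and compound 1 can be read from these two values. Among the compounds with values here, the one step that runs between measured neighbours is a 17-fold lower number from compound 2 to compound 3 (1.24 log units; beyond the scatter), and it is the only step that bears on the change now considered.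

Compound 4 `COc1ccc(-c2nc(-c3ccc(OC)c(OC)c3)cc3cc(C)ccc23)cc1` is not yet measured. It differs from compound 3 in one place: 4-methoxyphenyl in place of 3-aminophenyl on an aromatic carbon. This change removes the amino group whose arrival in the step from compound 2 to compound 3 went with the large drop in the number, and brings back a methoxy group, now as 4-methoxyphenyl rather than the 3-methoxyphenyl of compound 2. Compound 1 also carries a 4-methoxyphenyl at this place, but it differs from compound 4 elsewhere as well, so its value is only a loose pointer. The number for compound 4 in this assay is therefore expected to rise, by a step of about a 6.7-fold higher number from compound 3 to compound 4 (0.82 log units; beyond the scatter), to an estimated 3000 nM, within a range from 900 nM to 10000 nM.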

Compound 4, half-maximal inhibitory concentration: 3340 nM
The estimate for compound 4 lay 1.1-fold (0.05 log units) below the measured number; the range from low to high includes it.
By their numbers in this assay, from the lowest: compounds 3 and 1 (each within the scatter of the next); then compound 4; then compound 2.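

Replacing 3-aminophenyl with 4-methoxyphenyl at this place, next to the ring nitrogen, gives up most of what the amino group had gained in this assay, with a 7.4-fold higher number from compound 3 to compound 4 (0.87 log units; beyond the scatter). The low number of compound 3 therefore depends on the 3-aminophenyl group in two separate comparisons, since neither compound 2 with its 3-methoxyphenyl nor compound 4 with its 4-methoxyphenyl comes close to it. Within the data shown here, the new result also shows for the first time that the site of the methoxy group on this phenyl ring counts, with a 2.4-fold lower number from compound 2 to compound 4 (0.37 log units; beyond the scatter), although this shift is much smaller than the change from methoxy to amino in the earlier step, a 17-fold lower number from compound 2 to compound 3 (1.24 log units; beyond the scatter).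

Nothing available accounts for why these numbers move as they do. The compounds shown leave open whether the amino group would keep its advantage elsewhere on this phenyl ring, and how a hydroxyl, a dimethylamino group or a carboxylic acid at this place would compare with it.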